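The source may hold more compounds than are shown below. What is called first, only, known or untested is meant among the compounds shown, and "the series" means these compounds.

Compound 1 `O[C@@H](CCc1ccccc1)C[C@@H](O)CCc1ccccc1` gives 128 ug/mL in a functional assay on U-937 cells (Homo sapiens) for antiproliferative activity, read by MTT assay, with a stated time of 48 h; on this read-out higher numbers stand for weaker inhibition and lower numbers for stronger inhibition.
Compound 2 `Oc1ccc(CC[C@H](O)C[C@@H](O)CCc2ccccc2)cc1` gives 31.1 ug/mL in this assay.

Among the measured compounds shown here, of the two numbers measured so far, compound 2 has the lowest, and its nearest neighbour is compound 1: the step of a 4.1-fold lower number from compound 1 to compound 2 (0.61 log units; beyond the scatter) is the only one known, and it shows that placing a single small oxygen group on the aromatic ring lowered the number. Compound 3 `COc1cc(CC[C@H](O)C[C@@H](O)CCc2ccccc2)ccc1O` is not yet measured; compared with compound 2 it carries methoxy in place of hydrogen on an aromatic carbon, the new group sitting ortho to the hydroxy group that compound 2 already has. For the measured compounds named here, no measured pair shows what a methoxy does here, so the step from compound 1 to compound 2 is the only guide, and it is a loose one. Compound 3 is therefore expected to stay close to compound 2, with at most a modest change a 1.4-fold lower number from compound 2 to compound 3 (0.15 log units; within the scatter) in this assay, likely within the scatter. The estimate for compound 3 in this assay is 22 ug/mL, between 8 ug/mL and 60 ug/mL.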

Compound 3, half-maximal inhibitory concentration: 27.7 ug/mL
Compound 3: the middle estimate sits 1.3-fold (0.10 log units) below what was measured; the range from low to high includes it.
By their numbers in this assay, from the lowest: compounds 3 and 2 (each within the scatter of the next); then compound 1.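

In this assay, among the compounds shown here, the step of a 1.1-fold lower number from compound 2 to compound 3 (0.05 log units; within the scatter) is the first reading of what a methoxy does on this aromatic ring, and it leaves compound 2 and compound 3 indistinguishable. The position ortho to a hydroxy group therefore takes this group of 2 heavy atoms without a measurable difference, whereas the earlier step of a 4.1-fold lower number from compound 1 to compound 2 (0.61 log units; beyond the scatter), which put the hydroxy group on the same ring, lay beyond the scatter. Nothing available explains why the methoxy makes so little difference.

As far as these compounds go, whether an amine, a carboxylic acid or a longer chain such as butoxy at this position would give a different number remains open. So does whether a methoxy would have the same small effect on a ring without the hydroxy group.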